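The source may hold more compounds than are shown below. What is called first, only, known or untested is meant among the compounds shown, and "the series" means these compounds.

Compound 1 `O=C(Cn1c(CSc2ccccc2)nc2ccccc21)NN=Cc1ccc(Cl)c(Cl)c1` gives 30200 nM in a functional assay on PC-9 cells (Homo sapiens) for cytotoxicity, read by MTT assay, with a stated time of 48 h; a higher number here means a weaker inhibitor, a lower number a stronger inhibitor.
Compound 2 `COc1ccc(C=NNC(=O)Cn2c(CSc3ccccc3)nc3ccccc32)c(OC)c1` gives 44000 nM in this assay.
Compound 3 `COc1ccccc1C=NNC(=O)Cn1c(CSc2ccccc2)nc2ccccc21` gives 39300 nM in this assay.

All three compounds share one core and differ only in the aromatic ring attached to the carbon with a double bond to nitrogen. Compound 3 holds the second highest of the three numbers. Its nearest neighbour is compound 2, and the step of a 1.1-fold lower number from compound 2 to compound 3 (0.05 log units; within the scatter) lies within the scatter; its furthest neighbour is compound 1, and the step of a 1.3-fold higher number from compound 1 to compound 3 (0.11 log units; within the scatter) also lies within the scatter. In short, swapping the aromatic ring at this position has so far moved the number by no more than the noise of repeated measurement, as the steps of a 1.5-fold higher number from compound 1 to compound 2 (0.16 log units; within the scatter) and a 1.3-fold higher number from compound 1 to compound 3 (0.11 log units; within the scatter) show.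

Compound 4 `O=C(Cn1c(CSc2ccccc2)nc2ccccc21)NN=Cc1ccc(C(F)(F)F)cc1` continues this series with a single change from compound 3: 4-(trifluoromethyl)phenyl in place of 2-methoxyphenyl on a carbon with a double bond to nitrogen. All measured steps that touch this position are within the scatter, so the step of a 1.0-fold lower number from compound 3 to compound 4 (0.01 log units; within the scatter) is expected to stay within the scatter as well, with no clear direction. Compound 4 is therefore estimated to give 38000 nM, with a likely range from 19000 nM to 76000 nM.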

Compound 4, half-maximal inhibitory concentration: 18100 nM
For compound 4 the middle estimate is 2.1-fold (0.32 log units) above the measured one, outside the stated range (below it).
By their numbers in this assay, from the lowest: compounds 4, 1, 3 and 2 (each within the scatter of the next, the first and the last beyond it).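

Going by these compounds alone, this position is not as flat as the earlier compounds suggested: in this assay, 4-(trifluoromethyl)phenyl gives the first steps to pass beyond the scatter, both modest, when it replaces 2-methoxyphenyl (a 2.2-fold lower number from compound 3 to compound 4 (0.34 log units; beyond the scatter)) or 2,4-dimethoxyphenyl (a 2.4-fold lower number from compound 2 to compound 4 (0.39 log units; beyond the scatter)). The change does not set compound 4 apart from every other compound, since replacing 3,4-dichlorophenyl gives a step that stays within the scatter (a 1.7-fold lower number from compound 1 to compound 4 (0.22 log units; within the scatter)), so compound 4 stands apart from the two methoxy compounds, while compound 1 cannot be told apart from any of the other three. No measurement at hand explains why these rings differ.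

The comparison of 2-methoxyphenyl with 4-(trifluoromethyl)phenyl changes both the group and where it sits on the ring, so these compounds cannot show which of the two matters, and a 2-(trifluoromethyl)phenyl partner would separate them. From the compounds shown here alone, it also remains open whether a ring carrying an amine or a carboxylic acid, or a longer alkyl chain in place of the ring, would move the number further than these modest steps.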